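A few compounds are considered here, and "the series" means these few. Any claim that something is new, unique, unknown or untested is made for them only; others in the source may bear on it.

Compound 1 `N=C(NCCCc1c[nH]cn1)NCCC(c1ccccc1)c1ccccn1` gives 7.01 in a functional assay on ileum for antagonist activity at histamine H1 receptor (Cavia porcellus); on this read-out lower numbers stand for lower potency and higher numbers for higher potency (the scale is a negative logarithm). Compound 2 `Cc1ccc(CC(CC/N=C(\N)NCCCc2c[nH]cn2)c2ccccn2)cc1` gives 6.4 in this assay, a number lower than that of compound 1 by more than the usual scatter, so compound 1 holds the higher of the two values recorded so far. Compound 3 `N=C(NCCCc1c[nH]cn1)NCCC(c1ccc(Br)cc1)c1ccccn1` carries the change bromo in place of hydrogen on an aromatic carbon relative to compound 1, bromo in place of hydrogen on an aromatic carbon. Among the measured compounds shown here, with only two numbers in hand and none from a single-point change, the expected step of a number 0.09 log units higher from compound 1 to compound 3 (within the scatter) is small and not beyond the scatter. For compound 3 the estimate is 7.1, with a range from 6.6 to 7.6.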

Compound 3, negative logarithm of the antagonist equilibrium constant: 6.92
Beside the measured number, compound 3's estimate is 0.18 log units above it; measured number inside the range.
By their numbers in this assay, from the lowest: compound 2; then compounds 3 and 1 (each within the scatter of the next).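

Phenyl to 4-bromophenyl supplies the only one-place step in the series so far. In this assay, bromo in place of hydrogen on an aromatic carbon, para to a large group, gives a number 0.09 log units lower from compound 1 to compound 3 (within the scatter), so this position accepts a single bromine atom with the two values remaining within the scatter of each other. No available evidence bears on this result.

As far as these compounds go, whether an amine or a carboxylic acid at this position would also stay within the scatter remains open. So does the outcome of a longer chain there.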